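This account rests on a few compounds, and the source may have more. Where it says the series, first, only, none or still open, it means among the compounds named here.

Working notes on the series. Compound 2 `CC(C)COc1ccc(-c2cn3c(=O)n(-c4ccccc4)nc3c(N)n2)cc1` carries an isobutoxy group on the aryl ring attached to the shared core; in a functional assay on cells for antagonist activity at adenosine receptor A2b (Homo sapiens), read by cAMP accumulation, with a stated time of 10 min (on this read-out lower numbers stand for stronger inhibition and higher numbers for weaker inhibition), compound 2 has "not determined" (no result reported), so no number places it among the others. Compound 1 `C=CCOc1ccc(-c2cn3c(=O)n(-c4ccccc4)nc3c(N)n2)cc1` likewise has "not determined" (no result reported) in this assay. Compound 3 `O=c1[nH]c(-c2ccc(O)cc2)cn2c(=O)n(-c3ccccc3)nc12` differs from both in the core substituents and in the hydroxyl on the aryl ring; in this assay compound 3 gives only a limit, > 30000 nM, which is the limit noted as the limit of > 30000 nM in this assay, at which 1 of the 3 values shown sits. Within the data shown here, no pair of measured compounds differs in one place, so no measured step is available for the series.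

Compound 4 `C#CCOc1ccc(-c2cn3c(=O)n(-c4ccccc4)nc3c(N)n2)cc1` is reached from compound 2 by the change (ethynyl in place of isopropyl on a saturated chain carbon bound to an oxygen on an aromatic ring). Among the measured compounds shown here, with no measured step and no number for compound 2, the step in this assay can be expected only as one of unknown size, most plausibly none beyond the usual scatter. Compound 4 is estimated in this assay at 50 nM, with a range of 5 nM to 500 nM.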

Compound 4, half-maximal inhibitory concentration: > 30000 nM
Compound 4: no number, only a limit; the forecaster's own chance of this, stated with the estimate: 10%; at least 600-fold (2.77 log units) between middle value and limit.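

No step can be read between compound 2 and compound 4, as compound 2 has no single number. In this assay compound 4 gives only a limit, > 30000 nM. The compounds shown leave open how isobutoxy and propargyloxy compare in this assay.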